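Methoxy for methyl on the sulfonamide aryl group

The source may hold more compounds than are shown below. What is called first, only, known or untested is meant among the compounds shown, and "the series" means these compounds.

In a functional assay on MCF7 cells (Homo sapiens) for antiproliferative activity, read by MTT assay, with a stated time of 72 h (a higher number here means a weaker inhibitor, a lower number a stronger inhibitor), compound 3 `CCN(c1cccc(C)c1)S(=O)(=O)C1CC2OC1C(c1ccc(NC(=O)CCCCCCC(=O)O)cc1)=C2c1ccc(O)cc1` gives 31800 nM, within the scatter of compound 1 `CN(c1ccccc1)S(=O)(=O)C1CC2OC1C(c1ccc(NC(=O)CCCCCCC(=O)O)cc1)=C2c1ccc(O)cc1` at 63800 nM. Compound 2 `CN(c1cccc2ccccc12)S(=O)(=O)C1CC2OC1C(c1ccc(NC(=O)CCCCCCC(=O)O)cc1)=C2c1ccc(O)cc1` gives 14000 nM, the lowest number of the three. Compound 4 `CCN(c1cccc(OC)c1)S(=O)(=O)C1CC2OC1C(c1ccc(NC(=O)CCCCCCC(=O)O)cc1)=C2c1ccc(O)cc1` differs from compound 3 at one place (methoxy in place of methyl on an aromatic carbon), with 3-methylphenyl becoming 3-methoxyphenyl. Within the data shown here, no measured step isolates this swap. The nearest evidence is a 2.0-fold lower number from compound 1 to compound 3 (0.30 log units; within the scatter), which stays within the scatter while altering the same ring and the nitrogen substituent. The larger 4.6-fold lower number from compound 1 to compound 2 (0.66 log units; beyond the scatter) and a 2.3-fold higher number from compound 2 to compound 3 (0.36 log units; beyond the scatter) both involve naphthalen-1-yl, a much bigger change. No step beyond the scatter is therefore expected in this assay. The estimated step is a 1.1-fold lower number from compound 3 to compound 4 (0.03 log units; within the scatter). Compound 4 is expected at 30000 nM, with an estimated range of 14000 nM to 62000 nM.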

Compound 4, half-maximal inhibitory concentration: 37400 nM
Compound 4: the middle estimate sits 1.2-fold (0.10 log units) below what was measured; low and high end bracket the measured number.
By their numbers in this assay, from the lowest: compound 2; then compounds 3, 4 and 1 (each within the scatter of the next).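

In this assay the swap of methyl for methoxy on this aromatic carbon can now be read directly (a 1.2-fold higher number from compound 3 to compound 4 (0.07 log units; within the scatter)), and the added oxygen, with its hydrogen-bond acceptor, leaves the number within the scatter. The 3-methoxyphenyl compound stays separated from the naphthalen-1-yl compound (a 2.7-fold higher number from compound 2 to compound 4 (0.43 log units; beyond the scatter)) and is not separated from the phenyl compound (a 1.7-fold lower number from compound 1 to compound 4 (0.23 log units; within the scatter)), the same picture as the 3-methylphenyl compound gave. Nothing measured here offers an explanation for this result.

Still open, from the compounds shown here alone, is whether an amine or a carboxylic acid on the same aromatic carbon would also stay within the scatter of compound 3.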